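Moving the branch point of a butoxy chain

The compounds below may be only part of what the source reports. "The series", "measured", "known", "first", "only" and "open" are said of these compounds alone.

Measured in a functional assay on the whole organism with Rattus norvegicus as the target; a lower number here means that less compound is needed, a higher number that more compound is needed for the effect:
compound 1 `Oc1nc(-c2ccccc2)ncc1-c1nn[nH]n1`: 100 mg/kg
compound 2 `CC(C)COc1ccccc1-c1ncc(-c2nn[nH]n2)c(O)n1`: 0.1 mg/kg

Of the two, compound 2 has the lower number, so less of it is needed for the effect. Going by the values given here, one measured step bears on what comes next: isobutoxy in place of hydrogen on an aromatic carbon gave a 1000-fold lower number from compound 1 to compound 2 (3.00 log units; beyond the scatter), a large step.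

Compound 3 `CCC(C)Oc1ccccc1-c1ncc(-c2nn[nH]n2)c(O)n1` keeps the same atoms but joins them differently: sec-butyl in place of isobutyl on an oxygen on an aromatic ring. This is sec-butyl in place of isobutyl on an oxygen on an aromatic ring. Among the compounds with values here, no measured pair compares two such chains, so the evidence is thin. The chain stays, so a much smaller change than a 1000-fold lower number from compound 1 to compound 2 (3.00 log units; beyond the scatter) is expected in this assay, probably towards a somewhat higher number. The estimated change is a 3.0-fold higher number from compound 2 to compound 3 (0.48 log units; beyond the scatter). For compound 3 the expected value is 0.3 mg/kg, with an estimated range from 0.05 mg/kg to 2 mg/kg.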

Compound 3, dose for 50% inhibition: 0.05 mg/kg
Compound 3: middle estimate off by 6.0-fold (0.78 log units), on the high side; measured number inside the range.
By their numbers in this assay, from the lowest: compounds 3 and 2 (each within the scatter of the next); then compound 1.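

In this assay, changing isobutyl to sec-butyl on the oxygen gives a 2.0-fold lower number from compound 2 to compound 3 (0.30 log units; within the scatter), so this assay does not separate the two chains. The large effect of adding a chain at this position is therefore not confined to isobutoxy: with sec-butoxy as the added chain, the step is a 2000-fold lower number from compound 1 to compound 3 (3.30 log units; beyond the scatter), so moving the branch point leaves that effect in place. No supporting measurement is available to explain why these two chains read alike.

The compounds shown leave open whether branching is needed at all, since a straight n-butoxy chain would test that directly. They also leave open how the effect depends on chain size, which a shorter methoxy group or a longer hexyloxy chain at the same place would show.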